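Swapping a Phenyl for an Allyl on a Triazole Nitrogen

The source may hold more compounds than are shown below. What is called first, only, known or untested is meant among the compounds shown, and "the series" means these compounds.

Measured compounds:
compound 1, `C=CCn1c(SC/C(=N\O)c2ccccc2)nnc1-c1ccc(OC)c(OC)c1`: 58%
compound 2, `COc1ccc(-c2nnc(SCC(=O)c3ccccc3)n2-c2ccccc2)cc1OC`: 59%

In a functional assay on the whole organism (strain albino) for inhibition, with Rattus norvegicus as the target, read by paw edema, with a stated time of 3 h, at a dose of 0.28 mmol/kg by the oral route (on this read-out lower numbers stand for less inhibition and higher numbers for more inhibition at the one dose given (going by the name of the read-out)), compound 1 gives 58%. Compound 2 gives the top number of the two, yet compound 1 lies within the scatter of it, so the two cannot be told apart on these numbers. Compound 3, `C=CCn1c(SCC(=O)c2ccccc2)nnc1-c1ccc(OC)c(OC)c1`, has not been measured. It differs from compound 2 in one place: allyl in place of phenyl on an aromatic nitrogen. Among the measured compounds shown here, no step between two measured compounds is known here, so the size of this change in this assay must be guessed from what the two numbers show. Since both measured compounds sit close together, the step of a number 2 percentage points lower from compound 2 to compound 3 (within the scatter) is expected to be small, not beyond the scatter in either direction. Compound 3 is expected to give 57%, between 45% and 69%, because compound 1 with the same allyl gives 58%.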

Compound 3, a percentage reported as inhibition, in the whole organism at one dose (the size of the read-out at that dose, not a potency): 64%
Compound 3: middle estimate off by 7 percentage points, on the low side, within the range that was stated.
By their numbers in this assay, from the lowest: compounds 1, 2 and 3 (each within the scatter of the next).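

In this assay, the one-place change on this aromatic nitrogen now has a size: a number 5 percentage points higher from compound 2 to compound 3 (within the scatter), so an open allyl chain can stand where a phenyl ring stood without a step beyond the scatter. The change on the saturated chain carbon bound to a sulfur, where the oxime-bearing group gives way to the benzoylmethyl group, also stays inside that limit, with a number 6 percentage points higher from compound 1 to compound 3 (within the scatter). No measured evidence is available to explain either step.

Going by these compounds, what remains open is whether any group on this nitrogen can shift the read-out beyond the scatter, for instance a methyl, a longer chain such as butyl, or a chain ending in an amine. Each compound also has a reading at only one dose, so these values do not give a potency.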